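The source may hold more compounds than are shown below. What is called first, only, known or untested is meant among the compounds shown, and "the series" means these compounds.

The three measured compounds, each in a functional assay; a lower number here means a stronger inhibitor, a higher number a weaker inhibitor:

Compound 1 `CC(C)=CCOc1ccc2c(c1)OC(c1ccccc1F)CC2=O` gives 6360 nM.
Compound 2 `CC(C)=CCOc1ccc2c(c1)OC(c1cccc(F)c1)CC2=O` gives 4280 nM.
Compound 3 `CC(C)=CCOc1cc(O)c2c(c1)OC(c1ccccc1F)CC2=O` gives 5300 nM.

Compound 1 and compound 2 share a core and differ only in one place, where (3-fluorophenyl in place of 2-fluorophenyl on a saturated ring carbon). That change produced a 1.5-fold lower number from compound 1 to compound 2 (0.17 log units; within the scatter), so the two values cannot be told apart with confidence. Compound 3 is built on a second core, which differs from the core of compound 1 in that (hydroxy in place of hydrogen on an aromatic carbon); this too gave only a 1.2-fold lower number from compound 1 to compound 3 (0.08 log units; within the scatter). All three numbers sit close together, and none of the three compounds can be called stronger or weaker than another on this evidence.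

Compound 4 `CC(C)=CCOc1cc(O)c2c(c1)OC(c1cccc(F)c1)CC2=O` has not yet been measured. It stands to compound 3 as compound 2 stands to compound 1: in compound 4, (3-fluorophenyl in place of 2-fluorophenyl on a saturated ring carbon). The place of the change is described in the same words for both pairs, so it is the same change made on the second core. For the measured compounds named here, for compound 4 the expected step is a 1.4-fold lower number from compound 3 to compound 4 (0.14 log units; within the scatter), about the same size as the one seen from compound 1 to compound 2, which is the only guide available; since that earlier step stayed within the scatter, the expectation is only that compound 4 will come out near compound 3. Compound 4 is therefore estimated at 3800 nM, with a likely range from 1800 nM to 8000 nM.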

Compound 4, half-maximal inhibitory concentration: 7240 nM
Compound 4: the middle estimate sits 1.9-fold (0.28 log units) below what was measured; low and high end bracket the measured number.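

In this assay, 3-fluorophenyl in place of 2-fluorophenyl on the core that carries the hydroxy group gave a 1.4-fold higher number from compound 3 to compound 4 (0.14 log units; within the scatter), and this step cannot be told apart from the one on the core of compound 1: the same change on two cores in this assay, a 1.5-fold lower number (0.17 log units; within the scatter) from compound 1 to compound 2 and a 1.4-fold higher number (0.14 log units; within the scatter) from compound 3 to compound 4, 2.0-fold (0.31 log units) apart, within the scatter of two such steps. Hydroxy in place of hydrogen on an aromatic carbon gave a 1.7-fold higher number from compound 2 to compound 4 (0.23 log units; within the scatter), and this step likewise cannot be told apart from its earlier counterpart: the same change on two cores in this assay, a 1.2-fold lower number (0.08 log units; within the scatter) from compound 1 to compound 3 and a 1.7-fold higher number (0.23 log units; within the scatter) from compound 2 to compound 4, 2.0-fold (0.31 log units) apart, within the scatter of two such steps. The four compounds therefore give no sign that either change behaves differently on the two cores, but with every step within the scatter, they do not show that either change has a real effect here, nor that such an effect would carry over from one core to the other.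

The compounds shown leave open whether a step beyond the scatter could arise at all in this series, for instance with an unsubstituted phenyl or a chlorophenyl in place of the fluorophenyl, or with an amine or a carboxylic acid in place of the shared side chain. They also leave open whether a change with a clear effect would carry over between these two cores.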